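Swapping a Methylphenyl for a Hydroxyphenyl: Expected Outcome

This account rests on a few compounds, and the source may have more. Where it says the series, first, only, none or still open, it means among the compounds named here.

Compound 1 `O=C1O[C@H]([C@@H](O)Cn2cc(-c3cc(C(F)(F)F)cc(C(F)(F)F)c3)nn2)C(OCc2ccccc2)=C1OCc1ccccc1`: 45900 nM
Compound 2 `Cc1ccc(-c2cn(C/C=C3\OC(=O)C(OCc4ccccc4)=C3OCc3ccccc3)nn2)cc1`: > 100000 nM

In a functional assay on MCF7 cells (Homo sapiens) for antiproliferative activity, read by MTT assay, with a stated time of 72 h (on this read-out higher numbers stand for weaker inhibition and lower numbers for stronger inhibition), compound 1 gives 45900 nM. Compound 2 reaches only the assay limit of > 100000 nM, which is not a number; it sits at the limit of > 100000 nM in this assay, at which 1 of the 2 values shown sits. Compound 3 `O=C1O/C(=C\Cn2cc(-c3cccc(O)c3)nn2)C(OCc2ccccc2)=C1OCc1ccccc1` differs from compound 2 by 3-hydroxyphenyl in place of 4-methylphenyl on an aromatic carbon. For the measured compounds named here, no measured pair shows this kind of change, so there is no measured guide for its size. Compound 3 is expected to remain weak, close to where compound 2 stands, a step of an at least 1.1-fold lower number from compound 2 to compound 3 (0.04 log units; that floor lies within the scatter). The estimate for compound 3 is 90000 nM, between 30000 nM and 300000 nM.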

Compound 3, half-maximal inhibitory concentration: 27800 nM
The estimate for compound 3 lay 3.2-fold (0.51 log units) above the measured number; the measured number lies below the stated range.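

This position on the five-membered aromatic ring is not indifferent to the group it carries: in this assay, 3-hydroxyphenyl in place of 4-methylphenyl gives an at least 3.5-fold lower number from compound 2 to compound 3 (0.55 log units; beyond the scatter). On these data alone, that step is only a floor, and its true size is unknown. Compound 2 stands at a limit of the assay, not at a number: the limit of > 100000 nM in this assay, at which 1 of the 3 values shown sits.

The change swaps methyl for hydroxy and also moves the group on the phenyl ring, and the compounds shown cannot separate these two changes. As far as these compounds go, how a 3-methylphenyl or a 3-aminophenyl group would read here stays open.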